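Trifluoromethyl for fluoro in the second stereo series

The source may hold more compounds than are shown below. What is called first, only, known or untested is meant among the compounds shown, and "the series" means these compounds.

Compound 2 `COC(=O)N[C@H](C(=O)N1CCC[C@H]1C(=O)Nc1ccc([C@@H]2CC[C@@H](c3ccc(NC(=O)[C@@H]4CCCN4C(=O)[C@@H](NC(=O)OC)C(C)C)cc3)N2c2ccc(F)cc2)cc1)C(C)C` gives 2.6 h in an ADME assay on the whole organism for metabolic stability, with Rattus norvegicus as the target, at a dose of 3 mg/kg by the intravenous route (a lower number here means that the compound disappears faster, a higher number that the compound lasts longer), the lowest of the three numbers seen, though its gap to compound 3 is within the scatter. Compound 3 `COC(=O)N[C@H](C(=O)N1CCC[C@H]1C(=O)Nc1ccc([C@H]2CC[C@H](c3ccc(NC(=O)[C@@H]4CCCN4C(=O)[C@@H](NC(=O)OC)C(C)C)cc3)N2c2ccc(F)cc2)cc1)C(C)C` gives 3.3 h, and compound 1 `COC(=O)N[C@H](C(=O)N1CCC[C@H]1C(=O)Nc1ccc([C@H]2CC[C@H](c3ccc(NC(=O)[C@@H]4CCCN4C(=O)[C@@H](NC(=O)OC)C(C)C)cc3)N2c2ccc(C(F)(F)F)cc2)cc1)C(C)C` gives 4.2 h. Compound 4 `COC(=O)N[C@H](C(=O)N1CCC[C@H]1C(=O)Nc1ccc([C@@H]2CC[C@@H](c3ccc(NC(=O)[C@@H]4CCCN4C(=O)[C@@H](NC(=O)OC)C(C)C)cc3)N2c2ccc(C(F)(F)F)cc2)cc1)C(C)C` differs from compound 2 by trifluoromethyl in place of fluoro on an aromatic carbon.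

Going by the values given here, two measured steps bear on this. The change of aryl substituent is seen in reverse in a 1.3-fold lower number from compound 1 to compound 3 (0.10 log units; within the scatter), within the scatter. The configuration that sets compound 2 apart from compound 1 and compound 3 appears in a 1.3-fold higher number from compound 2 to compound 3 (0.10 log units; within the scatter), also within the scatter, a pair that, because of the fact that compounds 2 and 3 differ only in the configuration as drawn, isolates the stereochemical contribution. Neither step moves the half-life beyond the usual noise, so no step beyond the scatter is expected for compound 4 in this assay, with a slight lean upward mirroring the step from compound 1 to compound 3. Compound 4 is therefore expected at 3.2 h, within 1.8 h to 5.8 h. The expected step is a 1.2-fold higher number from compound 2 to compound 4 (0.09 log units; within the scatter).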

Compound 4, half-life: 6 h
Compound 4: middle estimate off by 1.9-fold (0.27 log units), on the low side; the whole stated range lies below it.
By their numbers in this assay, from the lowest: compounds 2, 3, 1 and 4 (each within the scatter of the next, the first and the last beyond it).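

In this assay, going by these compounds alone, trifluoromethyl in place of fluoro on an aromatic carbon now gives a step beyond the scatter, a 2.3-fold higher number from compound 2 to compound 4 (0.36 log units; beyond the scatter), whereas the earlier compounds showed this change only within the scatter. The result does not establish that the change behaves differently in the two stereo series, since the two steps remain within the scatter of each other: the same change on two cores in this assay, a 1.3-fold lower number (0.10 log units; within the scatter) from compound 1 to compound 3 and a 2.3-fold lower number (0.36 log units; beyond the scatter) from compound 4 to compound 2, 1.8-fold (0.26 log units) apart, within the scatter of two such steps. With trifluoromethyl in place, the difference in configuration again gives no step beyond the scatter, a 1.4-fold higher number from compound 1 to compound 4 (0.15 log units; within the scatter), and this pair isolates configuration: the fact that compounds 1 and 4 differ only in the configuration as drawn.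

On these data alone, it remains open whether an amine or a carboxylic acid on the same aromatic carbon would fall with the fluoro compounds or the trifluoromethyl compounds. A chloro or nitrile group at this place would test whether the step is specific to trifluoromethyl.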